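Removing the bromo from compound 2

The source may hold more compounds than are shown below. What is called first, only, known or untested is meant among the compounds shown, and "the series" means these compounds.

- Compound 1 (`C#CCNC(=O)c1csc(C#C)n1`), value 19200 nM as measured
- Compound 2 (`C#CCNC(=O)c1csc(Br)n1`), value > 40000 nM as a limit

In a functional assay on HCT-116 cells (Homo sapiens) for cytotoxicity, with a stated time of 3 days (on this read-out lower numbers stand for stronger inhibition and higher numbers for weaker inhibition), compound 2 gives > 40000 nM as a limit and not as a number. Compound 3 (`C#CCNC(=O)c1cscn1`) carries hydrogen in place of bromo on an aromatic carbon. Among the measured compounds shown here, the only measured step at this place swaps ethynyl for bromo (an at least 2.0-fold higher number from compound 1 to compound 2 (0.31 log units; beyond the scatter)) and does not involve hydrogen. On that single step, no change beyond the scatter is expected in this assay and the expected step is small (a number no higher from compound 2 to compound 3 (the limit leaves the size open)). For compound 3 the estimated value is 40000 nM (expected range 15000 nM to 100000 nM).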

Compound 3, half-maximal inhibitory concentration: > 40000 nM
Compound 3 ended at the assay's limit (the forecaster's own chance of this, stated with the estimate: 65%); the middle value lies on the limit itself.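

In this assay, compound 3 gives > 40000 nM, which is a limit of the assay and not a number. Ethynyl thus remains the only group shown on this aromatic carbon that gives a measured value, and the change to hydrogen gives an at least 2.0-fold higher number from compound 1 to compound 3 (0.31 log units; beyond the scatter). The step between compound 2 and compound 3 cannot be read, since both values are limits: the limit of > 40000 nM in this assay, at which 2 of the 3 values shown sit.

As far as these compounds go, whether an amine or a longer chain on this aromatic carbon would give a measured value stays open. So does the true size of any gap between compound 2 and compound 3.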